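A Longer Chain on the Sulfonyl of a Weak Urea

A few compounds are considered here, and "the series" means these few. Any claim that something is new, unique, unknown or untested is made for them only; others in the source may bear on it.

Compound 1 `CC(C)c1cccc(C(C)C)c1NC(=O)NS(=O)(=O)N1CCCC1` gives 15000 nM in an assay on liver for inhibition of sterol O-acyltransferase 1 (Rattus norvegicus), using microsomes; a higher number here means a weaker inhibitor, a lower number a stronger inhibitor. Compound 2 `CC(C)c1cccc(C(C)C)c1NC(=O)NS(=O)(=O)N(c1ccccc1)c1ccccc1` gives 16000 nM in this assay, and the two numbers lie within the usual scatter of each other, so neither compound stands apart from the other. Compound 3 `CCCCCCC(C)OS(=O)(=O)NC(=O)Nc1c(C(C)C)cccc1C(C)C` has not yet been measured. It differs from compound 1 in one place: (1-methylheptyl)oxy in place of pyrrolidin-1-yl on a sulfonyl sulfur. Within the data shown here, no measured pair shows what such a change does here. The step of a 2.5-fold lower number from compound 1 to compound 3 (0.40 log units; beyond the scatter) is expected to be a modest gain, somewhat beyond the scatter. Compound 3 is estimated to give 6000 nM, with a range from 1500 nM to 25000 nM.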

Compound 3, half-maximal inhibitory concentration: 35000 nM
Estimate against measurement, compound 3: 5.8-fold (0.77 log units) below; the measured number lies above the stated range.
By their numbers in this assay, from the lowest: compounds 1 and 2 (each within the scatter of the next); then compound 3.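

In this assay, the sulfonyl sulfur proves to be a place where a change can move the number: (1-methylheptyl)oxy in place of pyrrolidin-1-yl gives a 2.3-fold higher number from compound 1 to compound 3 (0.37 log units; beyond the scatter). This long, ringless chain therefore brings no gain to this weak urea, and the step runs toward weaker inhibition. Nothing measured here accounts for this step. Still open, going by these compounds, is which part of the change carries the step, the oxygen link or the chain. Also open, on these data alone, is how a shorter chain, such as isopropoxy, or a dimethylamino group would fare on the sulfonyl sulfur.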